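Benzyloxy replacement in a phenoxyethylamine series

This account rests on a few compounds, and the source may have more. Where it says the series, first, only, none or still open, it means among the compounds named here.

Compound 1 `COc1cccc(OC)c1OCCNCCOc1ccccc1OCc1ccccc1` gives 8.39 in a functional assay on Vas deferens for antagonist activity at Alpha-1A adrenergic receptor (Rattus norvegicus); a lower number here means a less potent compound, a higher number a more potent compound, by a factor of ten per unit of this negative logarithm. Among the measured compounds shown here, compound 2 `COc1cccc(OC)c1OCCNCCOc1ccccc1OCc1ccc(C)cc1` gives 8.23, the lower of the two numbers, with the only step of a number 0.16 log units lower from compound 1 to compound 2 (within the scatter) within the scatter. Compound 3 `COc1cccc(OC)c1OCCNCCOc1ccccc1OCc1ccccc1[N+](=O)[O-]` differs from compound 2 by 2-nitrophenyl in place of 4-methylphenyl on a saturated chain carbon bound to an oxygen on an aromatic ring. For the measured compounds named here, the one measured step concerns only a methyl on this ring and is within the scatter; no measured step covers a nitro group or this place. For compound 3 the expectation is therefore a step of about a number 0.13 log units lower from compound 2 to compound 3 (within the scatter), not beyond the scatter. The estimate for compound 3 is 8.1, range 7.4 to 8.8.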

Compound 3, negative logarithm of the antagonist equilibrium constant: 8.2
Beside the measured number, compound 3's estimate is 0.10 log units below it; measured number inside the range.
By their numbers in this assay, from the lowest: compounds 3, 2 and 1 (each within the scatter of the next).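

At the saturated chain carbon bound to an oxygen on an aromatic ring, 2-nitrophenyl in place of 4-methylphenyl gives a number 0.03 log units lower from compound 2 to compound 3 (within the scatter), and nitro in place of hydrogen gives a number 0.19 log units lower from compound 1 to compound 3 (within the scatter). In this assay this position therefore tolerates a group with 2 hydrogen-bond acceptors, as well as the earlier methyl, without a step beyond the scatter. No available data bear on why these numbers stay so close.

With 2-nitrophenyl and 4-methylphenyl differing in both group and ring place, the two effects remain unseparated; 4-nitrophenyl or 2-methylphenyl would divide them. As far as these compounds go, an amine or a carboxylic acid on this ring also remains open.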